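This account rests on a few compounds, and the source may have more. Where it says the series, first, only, none or still open, it means among the compounds named here.

In a functional assay on MT4 cells (Homo sapiens) for antiproliferative activity, read by MTT assay, with a stated time of 96 h (on this read-out lower numbers stand for an effect already at smaller amounts and higher numbers for an effect only at larger amounts of compound), compound 1 `N#C/C(=C\c1c(-c2ccccc2)[nH]c2ccccc12)C(=O)c1ccccc1` gives 500 nM and compound 2 `N#C/C(=C\c1c(-c2ccccc2)[nH]c2ccccc12)C(=O)c1cccs1` gives 400 nM; the two numbers lie within the usual scatter of each other, as the step of a 1.3-fold lower number from compound 1 to compound 2 (0.10 log units; within the scatter) shows, so compound 2 stands at the same level as compound 1. Compound 3 `COCCOC(=O)/C(C#N)=C/c1c(-c2ccccc2)[nH]c2ccccc12` differs from compound 2 by 2-methoxyethoxy in place of thiophen-2-yl on a carbonyl carbon. Within the data shown here, the one measured step only swapped one ring for another on the carbonyl carbon and does not reach this change, so the estimate rests on weak ground. Compound 3 is expected to shift by a 2.5-fold higher number from compound 2 to compound 3 (0.40 log units; beyond the scatter), giving an estimated 1000 nM in this assay, within a range from 300 nM to 4000 nM.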

Compound 3, half-maximal effective concentration: 1200 nM
Beside the measured number, compound 3's estimate is 1.2-fold (0.08 log units) below it; the measured number falls inside the stated range.
By their numbers in this assay, from the lowest: compounds 2 and 1 (each within the scatter of the next); then compound 3.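

Until now, changes at this position stayed within the scatter, but in this assay replacing either ring on the carbonyl carbon with the open 2-methoxyethoxy chain goes beyond it. The chain gives a 3.0-fold higher number from compound 2 to compound 3 (0.48 log units; beyond the scatter) and a 2.4-fold higher number from compound 1 to compound 3 (0.38 log units; beyond the scatter) as modest steps. So swapping one ring for the other left the number level, while giving up the ring for this chain raised it. No measurement here accounts for this shift.

On these data alone, whether the ring's departure or this particular chain drives the step stays open. So does how an amine, a carboxylic acid or a longer chain would read at this place.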